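The source may hold more compounds than are shown below. What is called first, only, known or untested is meant among the compounds shown, and "the series" means these compounds.

Compound 2 `COc1cc(C(=O)N(C)C)ccc1Nc1nc(OC2COC2)c2cc[nH]c2n1` is the weakest of the three measured compounds here. In a functional assay on CAL-51 cells (Homo sapiens) for antiproliferative activity, read by luminescence and CellTiter-Glo, with a stated time of 3 days (on this read-out lower numbers stand for stronger inhibition and higher numbers for weaker inhibition), compound 2 gives 1960 nM, the highest number of the set. Compound 3 `COc1cc(N2CCC(C)(O)CC2)ccc1Nc1nc(O[C@H]2CCOC(C)(C)C2)c2cc[nH]c2n1` gives 71 nM, and compound 1 `CN(C)C(=O)c1ccc(Nc2nc(O[C@H]3CC[C@@](C)(O)CC3)c3cc[nH]c3n2)c(OCC(F)(F)F)c1` gives 15 nM; both gaps to compound 2 lie well beyond the usual scatter.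

Compound 4 `COc1cc(C(=O)N(C)C)ccc1Nc1nc(OC2CCCCC2)c2cc[nH]c2n1` has not been measured. It differs from compound 2 in one place: cyclohexyl in place of oxetan-3-yl on an oxygen on an aromatic ring. For the measured compounds named here, no directly comparable pair of measured compounds shows the effect of exactly this change, so the expectation rests on the wider picture. Both compound 1 and compound 3, which each carry a six-membered non-aromatic ring rather than the small four-membered one, sit far lower than compound 2 in this assay.

On that basis the step from compound 2 to compound 4 is expected to be a clear drop, a 13-fold lower number from compound 2 to compound 4 (1.12 log units; beyond the scatter), beyond the scatter. Compound 4 is therefore estimated at 150 nM in this assay, with a plausible range from 40 nM to 600 nM.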

Compound 4, half-maximal inhibitory concentration: 190 nM
The estimate for compound 4 lay 1.3-fold (0.10 log units) below the measured number, and the stated range covers the measured number.
By their numbers in this assay, from the lowest: compound 1; then compound 3; then compound 4; then compound 2.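

In this assay, putting cyclohexyl in place of oxetan-3-yl gives a 10-fold lower number from compound 2 to compound 4 (1.01 log units; beyond the scatter) and leaves everything else in the molecule unchanged. For the compounds shown here, this is the first pair here that differs in one place only, so a large shift in this read-out can now be tied to this single position, the oxygen on the aromatic ring, rather than to several differences at once. Nothing measured here explains why the number falls. The change alters ring size and removes the ring oxygen together, so the step cannot say which of the two matters. A cyclobutyl group, a four-membered ring of carbon only, or a tetrahydropyran-4-yl group, a six-membered ring with one oxygen, would pull those two apart.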